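Replacing isopropoxy with cyclopropyloxy in an imidazoline series

The source may report more compounds than this note shows. Statements on the series, on what has been measured and on what is new or still open speak of the compounds shown alone.

Among the measured compounds shown here, compound 3 `CC(C)Oc1ccccc1OC(C)C1=NCCN1` is tested in an assay on CHO cells for displacement of a labelled ligand from Alpha-2C adrenergic receptor (Homo sapiens) (on this read-out lower numbers stand for stronger inhibition and higher numbers for weaker inhibition), and gives 398 nM, which is the highest of the three numbers so far, though its steps to both neighbours stay within the scatter. Compound 1 `CC(Oc1ccccc1Br)C1=NCCN1` gives 282 nM and compound 2 `CCc1ccccc1OC(C)C1=NCCN1` gives 288 nM. The step of a 1.4-fold higher number from compound 1 to compound 3 (0.15 log units; within the scatter) and the step of a 1.4-fold higher number from compound 2 to compound 3 (0.14 log units; within the scatter) show that varying this aromatic substituent has so far moved the numbers little. Compound 4 `CC(Oc1ccccc1OC1CC1)C1=NCCN1` carries cyclopropyl in place of isopropyl on an oxygen on an aromatic ring. For the measured compounds named here, since no measured step involving this substituent reached beyond the scatter, no step beyond the scatter is expected in this assay for compound 4, so that a 1.1-fold lower number from compound 3 to compound 4 (0.04 log units; within the scatter) is the expected step. Compound 4 is therefore estimated at 360 nM, within a range from 180 nM to 720 nM.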

Compound 4, inhibition constant: 676 nM
Compound 4: middle estimate off by 1.9-fold (0.27 log units), on the low side; low and high end bracket the measured number.
By their numbers in this assay, from the lowest: compounds 1, 2, 3 and 4 (each within the scatter of the next, the first and the last beyond it).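

In this assay the swap of isopropyl for cyclopropyl on an oxygen on an aromatic ring stays within the scatter, with a 1.7-fold higher number from compound 3 to compound 4 (0.23 log units; within the scatter) as its step. Cyclopropyloxy is still the first substituent here to separate modestly from others, through a 2.3-fold higher number from compound 2 to compound 4 (0.37 log units; beyond the scatter) and through a 2.4-fold higher number from compound 1 to compound 4 (0.38 log units; beyond the scatter) as well, while compound 3 remains within the scatter of all three other compounds. No evidence is available to explain this result. The compounds shown leave open how an amine, a carboxylic acid or a longer chain on this aromatic ring would read out.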